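Lengthening the Amine Chain on a Fused Core

The source may report more compounds than this note shows. Statements on the series, on what has been measured and on what is new or still open speak of the compounds shown alone.

Measured so far in a functional assay on A549 cells (Homo sapiens) for antiproliferative activity, read by MTT assay, with a stated time of 48 h; on this read-out higher numbers stand for weaker inhibition and lower numbers for stronger inhibition:
- compound 1, `CN(C)CCn1c(N)c(-c2nc3ccccc3[nH]2)c2nc(C#N)c(C#N)nc21`: compound 1 gives > 50000 nM, which is a limit of the assay rather than a number.
- compound 2, `CN(C)CCCn1c(N)c(-c2nc3ccccc3[nH]2)c2nc(C#N)c(C#N)nc21`: compound 2 gives 10400 nM.
- compound 3, `CN(C)CCCn1c(N)c(-c2nc3ccccc3s2)c2nc(C#N)c(C#N)nc21`: compound 3 gives 8870 nM.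

Between compound 1 and compound 2 the change is (dimethylamino)methyl in place of dimethylamino on a saturated chain carbon, two bonds along the chain from an aromatic nitrogen; this gives an at least 4.8-fold lower number from compound 1 to compound 2 (0.68 log units; beyond the scatter). Its true size is uncertain because the limit of > 50000 nM in this assay, at which 1 of the 3 values shown sits, hides how weak compound 1 really is. Between compound 2 and compound 3 the change is 1,3-benzothiazol-2-yl in place of 1H-benzimidazol-2-yl on an aromatic carbon, giving a 1.2-fold lower number from compound 2 to compound 3 (0.07 log units; within the scatter). The difference between the cores of compound 1 and compound 3 is not broken down here.

Compound 4, `CN(C)CCCCn1c(N)c(-c2nc3ccccc3s2)c2nc(C#N)c(C#N)nc21`, has not yet been measured. Its change from compound 3 is (dimethylamino)methyl in place of dimethylamino on a saturated chain carbon, three bonds along the chain from an aromatic nitrogen. For the measured compounds named here, this is the same kind of change as the one from compound 1 to compound 2, but the place differs: there the added carbon sat two bonds along the chain from an aromatic nitrogen, here three bonds along the chain. Since the earlier step started from a limit, its size is only a floor, and a further lengthening need not repeat it. For compound 4 a step of a 1.5-fold lower number from compound 3 to compound 4 (0.17 log units; within the scatter) is expected, a smaller gain than the earlier one. Compound 4 is therefore estimated at 6000 nM, with a likely range from 2500 nM to 15000 nM.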

Compound 4, half-maximal inhibitory concentration: 35800 nM
Estimate against measurement, compound 4: 6.0-fold (0.78 log units) below; the whole stated range lies below it.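

In this assay the one-carbon lengthening now goes the other way, with a 4.0-fold higher number from compound 3 to compound 4 (0.61 log units; beyond the scatter). Set beside the earlier lengthening, the two results clearly differ, so this change does not bring the same result wherever it is made in the series: the same change on two cores in this assay, an at least 4.8-fold lower number (0.68 log units; beyond the scatter) from compound 1 to compound 2 and a 4.0-fold higher number (0.61 log units; beyond the scatter) from compound 3 to compound 4, at least 19-fold (1.28 log units) apart, beyond the scatter of two such steps What this does not show is which difference matters, since the two steps sit at different places along the chain, one from 2-(dimethylamino)ethyl to 3-(dimethylamino)propyl and the other from 3-(dimethylamino)propyl to 4-(dimethylamino)butyl, and they also carry different groups on the shared core, 1H-benzimidazol-2-yl and 1,3-benzothiazol-2-yl; the size of the earlier step also stays unknown, with compound 1 resting on a limit and not a number: the limit of > 50000 nM in this assay, at which 1 of the 4 values shown sits.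

The compounds shown leave open whether the 4-(dimethylamino)butyl chain would give the same result with 1H-benzimidazol-2-yl on the core, a comparison that would separate the effect of the chain from that of the group on the core. Also open, as far as these compounds go, is how a chain longer than 4-(dimethylamino)butyl, or a pyrrolidine or morpholine in place of the dimethylamino group, would read on this measure.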